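This account rests on a few compounds, and the source may have more. Where it says the series, first, only, none or still open, it means among the compounds named here.

Measured so far in an ADME assay on cells (Hepatocyte, Rattus norvegicus) for metabolic stability; a lower number here means slower removal, a higher number faster removal of the compound:

Compound 1 `Cc1ccc2[nH]c(C(=O)N[C@H]3CN(S(=O)(=O)c4ccccc4)C[C@@H]3C(=O)N[C@H]3CCCNC3)cc2c1` gives 7 uL/min.
Compound 2 `Cc1csc(C(=O)N[C@H]2CN(S(=O)(=O)c3ccccc3)C[C@@H]2C(=O)N[C@H]2CCCNC2)n1` gives < 1 uL/min, which is a limit of the assay rather than a number (the limit of < 1 uL/min in this assay, at which 1 of the 3 values shown sits).
Compound 3 `O=C(N[C@H]1CN(S(=O)(=O)c2ccccc2)C[C@@H]1C(=O)N[C@H]1CCCNC1)c1nnc(-c2ccc(F)cc2)s1` gives 1.2 uL/min.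

Compound 3 holds the lowest of the two numbers; the nearest number is that of compound 1, with a 5.8-fold lower number from compound 1 to compound 3 (0.77 log units; beyond the scatter). Against compound 2 only a limit stands: an at least 1.2-fold higher number from compound 2 to compound 3 (0.07 log units; that floor lies within the scatter).

Compound 4 `O=C(N[C@H]1CN(S(=O)(=O)c2ccccc2)C[C@@H]1C(=O)N[C@H]1CCCNC1)c1cc(-c2ccc(Cl)cc2)on1` is not yet measured in this assay. It differs from compound 3 at the carbonyl carbon whose other neighbour is an amide-type nitrogen:

a group of 12 heavy atoms (9 carbon, 1 nitrogen, 1 oxygen, 1 chlorine; one five-membered aromatic ring with 2 hetero atoms, one six-membered aromatic ring of carbon only) in place of a group of 12 heavy atoms (8 carbon, 2 nitrogen, 1 fluorine, 1 sulfur; one five-membered aromatic ring with 3 hetero atoms, one six-membered aromatic ring of carbon only), on a carbonyl carbon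

All three measured steps swap the group on this same carbonyl carbon. Exchanging the larger bicyclic group of compound 1 for either smaller heteroaromatic group brought an at least 7.0-fold lower number from compound 1 to compound 2 (0.84 log units; beyond the scatter) and a 5.8-fold lower number from compound 1 to compound 3 (0.77 log units; beyond the scatter), both beyond the scatter. Between the two groups that carry a five-membered aromatic ring with hetero atoms, the step was an at least 1.2-fold higher number from compound 2 to compound 3 (0.07 log units; that floor lies within the scatter), whose floor lies within the scatter. The change from compound 3 to compound 4 keeps the heavy-atom count and the general shape; no measured step among these three compounds shows a swap of this kind moving the number beyond the scatter. Compound 4 is therefore expected to stay near compound 3, at an estimated 1.8 uL/min, with a range from 0.8 uL/min to 4.5 uL/min. The expected step is a 1.5-fold higher number from compound 3 to compound 4 (0.18 log units; within the scatter), within the scatter.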

Compound 4, intrinsic clearance in a liver preparation (reported as CLH), per the amount of preparation that the assay uses: 2.22 uL/min
The estimate for compound 4 lay 1.2-fold (0.09 log units) below the measured number, and the stated range covers the measured number.
By their numbers in this assay, from the lowest: compounds 3 and 4 (each within the scatter of the next); then compound 1. At a limit, below all of these: compound 2.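

In this assay, the 5-(4-chlorophenyl)-1,2-oxazol-3-yl group on the carbonyl carbon replaces the group of compound 3, changing the five-membered aromatic ring and the halogen in one exchange, and the result is a 1.9-fold higher number from compound 3 to compound 4 (0.27 log units; within the scatter), so this position tolerates at least this combined exchange without a change beyond the scatter. The lower number relative to the 5-methyl-1H-indol-2-yl group now extends to a third replacement, with a 3.2-fold lower number from compound 1 to compound 4 (0.50 log units; beyond the scatter), and among the compounds shown, compounds 2, 3 and 4 all follow this pattern and none goes against it. The position also gives the first separation beyond the scatter between two groups that both carry a five-membered aromatic ring with hetero atoms, at an at least 2.2-fold higher number from compound 2 to compound 4 (0.34 log units; beyond the scatter).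

On these data alone, the full size of that last step stays open, since compound 2 stands at a limit of the assay: the limit of < 1 uL/min in this assay, at which 1 of the 4 values shown sits. Also open is what the ring and the halogen each contribute on their own, and how the number responds when an amine or a carboxylic acid takes the place of the chlorine in the 5-(4-chlorophenyl)-1,2-oxazol-3-yl group.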